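The source may report more compounds than this note shows. Statements on the series, on what has been measured and on what is new or still open speak of the compounds shown alone.

Of the compounds shown here, three share one core and have been tested in a functional assay (FL5.12 cells, Mus musculus) with Apoptosis regulator Bcl-2 (Homo sapiens) as the target; a higher number here means that more compound is needed for the effect, a lower number that less compound is needed. Compound 1 `COc1ccccc1CC1(OC)CCN(c2ccc(C(=O)NS(=O)(=O)c3ccc(N[C@H](CCN(C)C)CSc4ccccc4)c([N+](=O)[O-])c3)cc2)CC1` gives 250 nM. Compound 2 `COC1(Cc2ccccc2Br)CCN(c2ccc(C(=O)NS(=O)(=O)c3ccc(N[C@H](CCN(C)C)CSc4ccccc4)c([N+](=O)[O-])c3)cc2)CC1` gives 200 nM in this assay. Compound 3 `CN(C)CC[C@H](CSc1ccccc1)Nc1ccc(S(=O)(=O)NC(=O)c2ccc(N3CCC(=Cc4ccc(F)cc4)CC3)cc2)cc1[N+](=O)[O-]` gives 600 nM in this assay, the highest of the three numbers, and its distance from compound 1 and from compound 2 lies beyond the scatter. Compound 4 `CN(C)CC[C@H](CSc1ccccc1)Nc1ccc(S(=O)(=O)NC(=O)c2ccc(N3CCC(=Cc4ccccc4Cl)CC3)cc2)cc1[N+](=O)[O-]` differs from compound 3 in one place: 2-chlorophenyl in place of 4-fluorophenyl on a double-bonded chain carbon bound to a double-bonded ring carbon. Going by the values given here, no measured step mirrors this change directly. Among the compounds with values here, the only step between close neighbours, a 1.3-fold lower number from compound 1 to compound 2 (0.10 log units; within the scatter), concerns a different pair of groups on an aromatic ring, yet it shows that exchanging one such group for another left the number essentially where it was. On that slim basis, the step from compound 3 to compound 4 is expected to be small, a 1.2-fold lower number from compound 3 to compound 4 (0.08 log units; within the scatter), with no direction that would clearly exceed the scatter. Compound 4 is therefore estimated at 500 nM in this assay, within a range from 200 nM to 1500 nM.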

Compound 4, half-maximal effective concentration: 450 nM
Beside the measured number, compound 4's estimate is 1.1-fold (0.05 log units) above it; the range from low to high includes it.
By their numbers in this assay, from the lowest: compounds 2, 1, 4 and 3 (each within the scatter of the next, the first and the last beyond it).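

In this assay, the exchange on a double-bonded chain carbon bound to a double-bonded ring carbon gives a 1.3-fold lower number from compound 3 to compound 4 (0.12 log units; within the scatter), so this position accepts 2-chlorophenyl in place of 4-fluorophenyl with no change that stands out from the scatter. Going by these compounds alone, until now, the only close comparison was a swap of methoxy for bromo on a different aromatic ring, so this is the first direct reading at this position. No measurement shown offers a reason for this result.

The two groups differ in both the halogen and its place on the ring, so 4-chlorophenyl and 2-fluorophenyl would be needed to separate these two changes. Going by these compounds, it also remains open how this position would respond to a phenyl ring with no halogen, or to one carrying an amine or a carboxylic acid.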